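A few compounds are considered here, and "the series" means these few. Any claim that something is new, unique, unknown or untested is made for them only; others in the source may bear on it.

In a functional assay on MCF7 cells (Homo sapiens) for cytotoxicity, with a stated time of 3 days (a lower number here means a stronger inhibitor, a higher number a weaker inhibitor), three compounds built on a shared core have been measured. Compound 1 (`c1csc(-c2cc(-c3ccoc3)cc(-c3cccs3)n2)c1`) gives > 100000 nM, a limit of the assay and not a number. Compound 2 (`Clc1ccc(-c2cc(-c3ccsc3)nc(-c3cccs3)c2)o1`) gives > 100000 nM, also a limit. Compound 3 (`Cc1ccsc1-c1cc(-c2ccco2)cc(-c2cccs2)n1`) gives > 100000 nM, again a limit. It therefore stands with the others at the limit of > 100000 nM in this assay, at which 3 of the 3 values shown sit. Compound 4 (`Cc1ccsc1-c1cc(-c2ccco2)cc(-c2sccc2C)n1`) differs from compound 3 by methyl in place of hydrogen on an aromatic carbon, turning thiophen-2-yl into 3-methylthiophen-2-yl: methyl in place of hydrogen on an aromatic carbon. For the measured compounds named here, no measured step shows the effect of this change, so no shift beyond the scatter is expected in this assay. The expected change is a number no higher from compound 3 to compound 4 (the limit leaves the size open). Compound 4 is estimated at 100000 nM, with an expected range from 30000 nM to 200000 nM.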

Compound 4, half-maximal inhibitory concentration: > 100000 nM
Compound 4: no number, only a limit (the forecaster's own chance of this, stated with the estimate: 80%); the middle value sits exactly at the limit.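

For the compounds shown here, compound 3 and compound 4 both rest on a limit and not a number, so no step between them can be read in this assay. The compounds shown leave open whether any change to the shared core gives a measurable value: the limit of > 100000 nM in this assay, at which 4 of the 4 values shown sit.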